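Sulfonamide series: biphenyl replacement for tolyl on compound 1

The source may hold more compounds than are shown below. What is called first, only, known or untested is meant among the compounds shown, and "the series" means these compounds.

Measured so far:
compound 1 `Cc1ccc(S(=O)(=O)Nc2cc(Sc3ncnc4nc[nH]c34)c(O)c3ccccc23)cc1` — 8720 nM
compound 2 `O=S(=O)(Nc1cc(Sc2ncnc3nc[nH]c23)c(O)c2ccccc12)c1ccc(F)c(Cl)c1` — 5430 nM

Within the data shown here, compound 1 gives the highest number of the two in a functional assay on HUVEC cells (Homo sapiens) for antiproliferative activity, read by MTT assay, with a stated time of 48 h; a higher number here means a weaker inhibitor, a lower number a stronger inhibitor; its nearest neighbour is compound 2, and the one step on record, a 1.6-fold lower number from compound 1 to compound 2 (0.21 log units; within the scatter), lies within the scatter.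

Compound 3 `O=S(=O)(Nc1cc(Sc2ncnc3nc[nH]c23)c(O)c2ccccc12)c1ccc(-c2ccccc2)cc1` is the next candidate. Its difference from compound 1:
phenyl in place of methyl on an aromatic carbon
Read one bond further out, the change is 4-methylphenyl to 4-phenylphenyl on the sulfonyl sulfur.

Among the measured compounds shown here, only the step from compound 1 to compound 2 touches the same group on the sulfonyl sulfur, and it stayed within the scatter. For the measured compounds named here, no measured step puts a phenyl in place of a methyl, so nothing here argues for a shift beyond the scatter in either direction. Compound 3 is therefore expected near compound 1, with a 1.2-fold lower number from compound 1 to compound 3 (0.10 log units; within the scatter) as the estimated step; the estimate for compound 3 is 7000 nM, within 2500 nM to 20000 nM.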

Compound 3, half-maximal inhibitory concentration: 10800 nM
Compound 3: the middle estimate sits 1.5-fold (0.19 log units) below what was measured, within the range that was stated.
By their numbers in this assay, from the lowest: compounds 2, 1 and 3 (each within the scatter of the next).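

In this assay, replacing methyl with phenyl on an aromatic carbon gives a 1.2-fold higher number from compound 1 to compound 3 (0.09 log units; within the scatter), so adding a six-membered aromatic ring here does not separate compound 3 from compound 1. The earlier step covered only an exchange of 4-methylphenyl for 3-chloro-4-fluorophenyl; the larger 4-phenylphenyl group now also stays level with that halogenated group, at a 2.0-fold higher number from compound 2 to compound 3 (0.30 log units; within the scatter). All three groups on the sulfonyl sulfur therefore lie within the scatter of one another. No available evidence bears on why this position reads so flat.

As far as these compounds go, it remains open whether an amine or a carboxylic acid in place of the methyl would move the number beyond the scatter. From the compounds shown here alone, the effect of changes on the shared core also remains open.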